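Chloro in place of methyl: compound 2 to compound 3

A few compounds are considered here, and "the series" means these few. Any claim that something is new, unique, unknown or untested is made for them only; others in the source may bear on it.

Measured so far in an ADME assay on L6 cells (Rattus norvegicus) for cytotoxicity; a higher number here means a weaker inhibitor, a lower number a stronger inhibitor:
- compound 1 `O=C(NCCn1cnc([N+](=O)[O-])n1)c1ccc(C(F)(F)F)cc1` gives > 273000 nM, which is a limit of the assay and not a number
- compound 2 `Cc1ccc2nc(NC(=O)Cn3cnc([N+](=O)[O-])n3)sc2c1` gives 170000 nM as a measured value

For the measured compounds named here, compound 2 at 170000 nM holds the only actual number. Compound 1 reaches only a limit of the assay, so no ranking can be drawn from it.

Compound 3 `O=C(Cn1cnc([N+](=O)[O-])n1)Nc1nc2ccc(Cl)cc2s1` keeps the shared core of compound 2 and differs in one place: chloro in place of methyl on an aromatic carbon, with chloro in place of methyl on an aromatic carbon. Going by the values given here, no measured step between close relatives exists here, so the expectation rests only on compound 2 at 170000 nM and on this single exchange. No shift beyond the usual scatter is expected in this assay, and the expected 1.2-fold lower number from compound 2 to compound 3 (0.08 log units; within the scatter) is small. For compound 3 the estimated value is 140000 nM, with an expected range from 60000 nM to 270000 nM in this assay.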

Compound 3, half-maximal inhibitory concentration: 163000 nM
For compound 3 the middle estimate is 1.2-fold (0.07 log units) below the measured one, within the range that was stated.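

In this assay the series now has its first readable step, for chloro in place of methyl on an aromatic carbon: a 1.0-fold lower number from compound 2 to compound 3 (0.02 log units; within the scatter). At this position on the six-membered aromatic ring of carbon only, compound 2 and compound 3 therefore read as equal, so this exchange gives no measurable separation in this assay. Compound 1 still offers no number for comparison, as its entry is a limit of the assay: the limit of > 273000 nM in this assay, at which 1 of the 3 values shown sits.

From the compounds shown here alone, whether an amine, a carboxylic acid or a longer chain at the same position would also read alike remains open. The pair also leaves open whether chloro in place of methyl would read the same at another position on the ring or with a different group on the shared core.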